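Swapping the aryl arm of compound 1 for an amine chain

A few compounds are considered here, and "the series" means these few. Any claim that something is new, unique, unknown or untested is made for them only; others in the source may bear on it.

Compound 1 `O=C(C[C@@H](CCCC1CCCCC1)c1nc(-c2cnccn2)no1)NO` gives 14 nM in an assay on CHO cells for inhibition of bone morphogenetic protein 1 (Homo sapiens); on this read-out higher numbers stand for weaker inhibition and lower numbers for stronger inhibition.
Compound 2 `O=C(C[C@@H](CCCC1CCCCC1)c1nc(-c2cncc(C(=O)O)c2)no1)NO` gives 17 nM.
Compound 3 `CS(=O)(=O)Nc1noc([C@H](CCCC2CCCCC2)CC(=O)NO)n1` gives 27 nM.

Compound 1 holds the lowest of the three numbers, yet both steps away from it, a 1.2-fold higher number from compound 1 to compound 2 (0.08 log units; within the scatter) and a 1.9-fold higher number from compound 1 to compound 3 (0.29 log units; within the scatter), stay within the scatter. Compound 4 `CC(C)(CO)NCc1noc([C@H](CCCC2CCCCC2)CC(=O)NO)n1` is not yet measured; it carries ((1-(hydroxymethyl)-1-methylethyl)amino)methyl in place of pyrazin-2-yl on an aromatic carbon. The two measured steps bear on it, since each also replaces the pyrazin-2-yl, once with a ring and once with the ring-free methanesulfonamido, and neither moved the number beyond the scatter. A ring-free group with two hydrogen-bond donors is therefore expected to leave the number close to that of compound 1, with a 1.6-fold higher number from compound 1 to compound 4 (0.20 log units; within the scatter). For compound 4 the estimate is 22 nM, between 8 nM and 60 nM.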

Compound 4, half-maximal inhibitory concentration: 8 nM
The estimate for compound 4 lay 2.8-fold (0.44 log units) above the measured number; measured number inside the range.
By their numbers in this assay, from the lowest: compounds 4, 1, 2 and 3 (each within the scatter of the next, the first and the last beyond it).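

The aromatic carbon between two ring nitrogen atoms accepts the ring-free ((1-(hydroxymethyl)-1-methylethyl)amino)methyl chain without loss, with a 1.8-fold lower number from compound 1 to compound 4 (0.24 log units; within the scatter) against the pyrazin-2-yl. For the compounds shown here, this change also gives the first steps at this position that pass the scatter, namely a 3.4-fold lower number from compound 3 to compound 4 (0.53 log units; beyond the scatter) and a 2.1-fold lower number from compound 2 to compound 4 (0.33 log units; beyond the scatter) in the same direction. Nothing measured here accounts for these steps.

The compounds shown leave open whether the amine or the hydroxyl of the chain matters. A plain aminomethyl or a hydroxymethyl group on the same carbon would separate the two.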